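A few compounds are considered here, and "the series" means these few. Any claim that something is new, unique, unknown or untested is made for them only; others in the source may bear on it.

Measured so far:
- Compound 1 `COc1c(Nc2ccc(S(C)(=O)=O)cc2F)ncnc1OC1C[C@@H]2COC[C@@H](C1)N2C(=O)OC1(C)CC1` gives 73%
- Compound 2 `CC1(OC(=O)N2CC3COCC(C2)C3Oc2ncnc(Oc3ccccc3F)c2F)CC1` gives 114%

Going by the values given here, in a functional assay on HEK293 cells for agonist activity at Glucose-dependent insulinotropic receptor (Homo sapiens), read by cAMP accumulation, with a stated time of 30 min (on this read-out lower numbers stand for smaller maximal responses and higher numbers for larger maximal responses), compound 2 stands highest of the two numbers so far, and the nearest number, that of compound 1, is lower by a margin that goes beyond the usual scatter. Among the compounds with values here, compound 1 and compound 2 differ in several places at once, so no single step between measured compounds can be read from the pair; the two values simply show that compound 2 reaches the larger maximal response.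

Compound 3 `CC1(OC(=O)N2CC3COCC(C2)C3Oc2ncnc(Nc3ccc(F)cc3F)c2F)CC1` has not yet been measured. It differs from compound 2 in one place:
(2,4-difluorophenyl)amino in place of 2-fluorophenoxy on an aromatic carbon

A group joined through nitrogen, as in compound 3, is also what compound 1 carries, and compound 1 gives 73%; this is the only hint available, and it is indirect. A downward step in this assay of moderate size is therefore expected, with the possibility that the change stays within the scatter. Compound 3 is expected to give 90%, with a range from 60% to 115%. That corresponds to an expected step of a number 24 percentage points lower from compound 2 to compound 3 (beyond the scatter).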

Compound 3, largest response reached (reported as percent of maximum), in percent of the reference or control that the assay uses: 94%
Beside the measured number, compound 3's estimate is 4 percentage points below it; the measured number falls inside the stated range.
By their numbers in this assay, from the lowest: compound 1; then compound 3; then compound 2.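

In this assay, replacing 2-fluorophenoxy with (2,4-difluorophenyl)amino on the aromatic carbon next to the ring nitrogen gives a number 20 percentage points lower from compound 2 to compound 3 (beyond the scatter), a modest step. Going by these compounds alone, this pair differs in one place only, so it gives the first direct reading of a change at this position, which the comparison of the two earlier compounds could not provide: the new group lowers the maximal response by a measurable amount, yet the receptor is still clearly activated. The change is a combined one, however, since the incoming group brings a nitrogen link with one hydrogen-bond donor in place of the oxygen link and also carries a second fluorine on the aromatic ring, and nothing available explains why the response falls.

The compounds shown leave open how much of the step belongs to the nitrogen link and how much to the added fluorine, a question that a plain 2-fluorophenylamino group at the same position could help to separate. They also leave open how this position would respond to a different kind of group, such as a morpholine, a simple alkylamine or a sulfur-linked 2-fluorophenyl group.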